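Amino in Place of Benzyloxy at the Sulfonyl-Bearing Ring

This account rests on a few compounds, and the source may have more. Where it says the series, first, only, none or still open, it means among the compounds named here.

Measured so far:
compound 1, `Cc1cc(SC(C)(C)C)c(S(C)(=O)=O)cc1C(=O)N=C(N)N`, 22 nM
compound 2, `Cc1cc(OCc2ccccc2)c(S(C)(=O)=O)cc1C(=O)N=C(N)N`, 28 nM

Both numbers come from a functional assay for inhibition of sodium/hydrogen exchanger (Oryctolagus cuniculus); on this read-out higher numbers stand for weaker inhibition and lower numbers for stronger inhibition. Going by the values given here, compound 2 has the highest of the two numbers, but its only neighbour, compound 1, sits within the scatter, so the two cannot be told apart.

Compound 3, `Cc1cc(N)c(S(C)(=O)=O)cc1C(=O)N=C(N)N`, differs from compound 2 by amino in place of benzyloxy on an aromatic carbon.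

Among the compounds with values here, the only measured step at that same position is a 1.3-fold higher number from compound 1 to compound 2 (0.10 log units; within the scatter). That step swapped one large group for another and moved the number only within the scatter. Nothing measured shows a small group at this place, so that step bears on the present one only loosely. The step from compound 2 to compound 3 is therefore expected to be small, estimated as a 1.4-fold higher number from compound 2 to compound 3 (0.15 log units; within the scatter), with a wide range to allow for the unknown effect of a much smaller group. Compound 3 is estimated at 40 nM, between 15 nM and 120 nM.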

Compound 3, half-maximal inhibitory concentration: 16 nM
The estimate for compound 3 lay 2.5-fold (0.40 log units) above the measured number; the measured number falls inside the stated range.
By their numbers in this assay, from the lowest: compounds 3, 1 and 2 (each within the scatter of the next).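

Replacing benzyloxy with amino removes the aromatic ring and leaves a single heavy atom at this place, yet this assay shows only a 1.8-fold lower number from compound 2 to compound 3 (0.24 log units; within the scatter) for that change. Set against the other large group, the swap gives a 1.4-fold lower number from compound 1 to compound 3 (0.14 log units; within the scatter), so all three compounds stay within the scatter of one another, and a large group at this place is not required to keep the number at this level in these compounds. Nothing available here explains why such different groups give such close numbers.

The compounds shown leave open what a carboxylic acid or a longer alkyl chain would do at this place. On these data alone, it is also open whether a methylamino or dimethylamino group would keep the number in the same range as amino.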